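The source may hold more compounds than are shown below. What is called first, only, known or untested is meant among the compounds shown, and "the series" means these compounds.

In a functional assay on the whole organism (strain Sprague-Dawley) for inhibition, with Rattus norvegicus as the target, read by paw edema, with stated times of 30 min and 2 h, at a dose of 80 mg/kg by the oral route (a higher number here means more inhibition at the dose given (going by the name of the read-out), a lower number less inhibition), compound 1 `Cc1ccc(S(=O)(=O)Nn2c(C)nc3ccccc3c2=O)cc1` gives 24.2%. Compound 2 `Cc1nc2ccccc2c(=O)n1NC(=O)NC(C)(C)C` gives 29.8% in this assay; the difference between the cores of compound 1 and compound 2 is not broken down here. Compound 3 `Cc1ccc(S(=O)(=O)Nn2c(CO[N+](=O)[O-])nc3ccccc3c2=O)cc1`, which carries nitrooxy in place of hydrogen on a saturated chain carbon bound to an aromatic carbon, gives 15.7% in this assay, a change described as a number 8.5 percentage points lower from compound 1 to compound 3 (within the scatter). The values of compound 2 and compound 3 lie beyond the usual scatter of each other.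

Compound 4 `CC(C)(C)NC(=O)Nn1c(CO[N+](=O)[O-])nc2ccccc2c1=O` is not yet measured; it differs from compound 2 by nitrooxy in place of hydrogen on a saturated chain carbon bound to an aromatic carbon, the same change that separates compound 1 from compound 3. Among the measured compounds shown here, a step of a number 7.8 percentage points lower from compound 2 to compound 4 (within the scatter) is expected for this assay, resting on the single earlier example a number 8.5 percentage points lower from compound 1 to compound 3 (within the scatter). On this basis compound 4 is estimated to give 22% in this assay, with a range from 10% to 34%.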

Compound 4, a percentage reported as inhibition, in the whole organism at one dose (the size of the read-out at that dose, not a potency): 14.1%
Estimate against measurement, compound 4: 7.9 percentage points above; low and high end bracket the measured number.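

The new pair shows a number 15.7 percentage points lower from compound 2 to compound 4 (beyond the scatter) in this assay for nitrooxy in place of hydrogen on a saturated chain carbon bound to an aromatic carbon. Set beside the earlier pair, this step does not differ from it by more than the scatter of two such steps, so the change can be read as carrying across these two cores: the same change on two cores in this assay, a number 8.5 percentage points lower (within the scatter) from compound 1 to compound 3 and a number 15.7 percentage points lower (beyond the scatter) from compound 2 to compound 4, 7.2 percentage points apart, within the scatter of two such steps. Two pairs at a single dose show no more than that: they fix no size for the step on any other core, and they do not show why it arises. The compounds shown leave open what a longer chain bearing nitrooxy, or an amine or a carboxylic acid in the same place, would give.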